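Pyridyl ether swap on a benzimidazole acid: permeability outlook

The source may hold more compounds than are shown below. What is called first, only, known or untested is meant among the compounds shown, and "the series" means these compounds.

Compound 1, `Cc1ccc(Oc2ccc3nc(COc4cccc(C(=O)O)c4)n(C)c3n2)cc1C`: 12.4 10^-6 cm/s
Compound 2, `Cn1c(COc2cccc(C(=O)O)c2)nc2cnc(Oc3ccc4c(c3)CCC4)cc21`: 16.5 10^-6 cm/s
Compound 3, `Cn1c(COc2cccc(C(=O)O)c2)nc2ccc(Oc3ccc(Cl)cn3)cc21`: 16.2 10^-6 cm/s

In an ADME assay for permeability, using PAMPA, with a stated time of 4 h (on this read-out lower numbers stand for lower permeability and higher numbers for higher permeability), the three measured compounds give numbers that lie within the usual scatter of one another. Compound 3 stands next to compound 2, and its gap to compound 1 also falls within that scatter, so no ordering among the three can be read from these values.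

Compound 4, `Cc1cccnc1Oc1ccc2nc(COc3cccc(C(=O)O)c3)n(C)c2c1`, has not yet been measured. It differs from compound 3 in one place: 3-methylpyridin-2-yl in place of 5-chloropyridin-2-yl on an oxygen on an aromatic ring. Both groups are six-membered aromatic rings with one hetero atom, with no hydrogen-bond donor and one hydrogen-bond acceptor, and they sit on the same oxygen on the same aromatic ring of the shared core.

Among the measured compounds shown here, no measured pair shows a step of this kind, so the expectation rests on the closeness of the three numbers already in hand. In this assay the step of a 1.2-fold lower number from compound 3 to compound 4 (0.06 log units; within the scatter) is expected to stay within the scatter, with no clear direction. Compound 4 is therefore estimated at 14 10^-6 cm/s, with a range from 8 10^-6 cm/s to 24 10^-6 cm/s.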

Compound 4, apparent permeability: 6 10^-6 cm/s
Compound 4: middle estimate off by 2.3-fold (0.37 log units), on the high side; the measured number lies below the stated range.
By their numbers in this assay, from the lowest: compound 4; then compounds 1, 3 and 2 (each within the scatter of the next).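

On an oxygen on an aromatic ring, replacing 5-chloropyridin-2-yl with 3-methylpyridin-2-yl gives in this assay a 2.7-fold lower number from compound 3 to compound 4 (0.43 log units; beyond the scatter) and so opens the only gap in this set that is not lost in the scatter. The two groups match in heavy atoms, ring type, hydrogen-bond donors and acceptors, so these counts alone do not settle the read-out at this place. Nothing in hand explains the step.

The step changes both the substituent and where it sits on the pyridine ring, and the compounds shown do not separate these two differences. As far as these compounds go, it remains open whether unsubstituted pyridin-2-yl, 5-methylpyridin-2-yl or 3-chloropyridin-2-yl on the same oxygen would read closer to compound 3 or to compound 4.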